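This account rests on a few compounds, and the source may have more. Where it says the series, first, only, none or still open, it means among the compounds named here.

Measured in a functional assay on SW480 cells (Homo sapiens) for cytotoxicity, read by sulforhodamine B assay, with a stated time of 48 h; a lower number here means a stronger inhibitor, a higher number a weaker inhibitor:

- compound 1 `COc1ccc(/C=C/C(=O)c2ccc(NC(C)=O)c(-c3ccc(F)cc3)c2)cc1OC`: 5350 nM
- compound 2 `COc1cc(/C=C/C(=O)c2ccc(N)c(-c3ccc(F)cc3)c2)ccc1O`: 8350 nM
- compound 3 `COc1ccc(/C=C/C(=O)c2ccc(N)c(-c3ccc(F)cc3)c2)cc1`: 7230 nM

These three values all lie within the usual scatter of one another. Compound 3, at 7230 nM, therefore cannot be told apart from compound 1 or compound 2, and the set shows no ranking.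

Compound 4 `COc1ccc(/C=C/C(=O)c2ccc(N)c(-c3ccc(F)cc3)c2)cc1OC` is compound 3 with methoxy in place of hydrogen on an aromatic carbon. That carbon belongs to a six-membered aromatic ring of carbon only, and the new group sits ortho to a methoxy group and meta to a large group.

Going by the values given here, only one measured step touches this part of the molecule. With 4-methoxyphenyl in place of 4-hydroxy-3-methoxyphenyl, it gave a 1.2-fold lower number from compound 2 to compound 3 (0.06 log units; within the scatter), a change within the scatter. Compound 4 also shares its methoxy groups with compound 1, which has an acetamide instead of the free amine and gives 5350 nM. Neither comparison suggests that this edit matters much in this assay, so no shift beyond the scatter is expected. The expected step is a 1.1-fold lower number from compound 3 to compound 4 (0.05 log units; within the scatter). For compound 4 the estimated value is 6500 nM, with an expected range from 3500 nM to 12000 nM.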

Compound 4, half-maximal inhibitory concentration: 6640 nM
Compound 4: the middle estimate sits 1.0-fold (0.01 log units) below what was measured, within the range that was stated.
By their numbers in this assay, from the lowest: compounds 1, 4, 3 and 2 (each within the scatter of the next).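

In this assay, filling this ring carbon, ortho to a methoxy group, with a further methoxy gives a 1.1-fold lower number from compound 3 to compound 4 (0.04 log units; within the scatter), so in this pair the added group leaves a difference too small to read. The new compound also links the neighbouring edits: capping the hydroxy group as its methyl ether, with methyl in place of hydrogen on the oxygen, gives a 1.3-fold lower number from compound 2 to compound 4 (0.10 log units; within the scatter), which means compound 2, compound 3 and compound 4 cannot be told apart despite their different ring substituents. Going by these compounds alone, it also gives the first single-place comparison of the free amine with the acetamide, and removing the acetyl group gives a 1.2-fold higher number from compound 1 to compound 4 (0.09 log units; within the scatter), so that nitrogen edit cannot be read as mattering here either.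

No measurement at hand accounts for how close these numbers lie. Still open, from the compounds shown here alone, is whether a group of another kind at this ring carbon, such as a carboxylic acid, an amine or a longer chain like butoxy, would move the number beyond the scatter.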